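The source may hold more compounds than are shown below. What is called first, only, known or untested is meant among the compounds shown, and "the series" means these compounds.

The series shares one core, with the variable group on a sulfur whose other neighbour is a saturated chain carbon. Compound 1 `Cc1ccc(SCc2ccc(/C=C/C(=O)Nc3ccccc3N)cc2)cc1` carries 4-methylphenyl there, compound 2 `COc1ccc(SCc2ccc(/C=C/C(=O)Nc3ccccc3N)cc2)cc1OC` carries 3,4-dimethoxyphenyl and compound 3 `Cc1cc(C)cc(SCc2ccc(/C=C/C(=O)Nc3ccccc3N)cc2)c1` carries 3,5-dimethylphenyl. In a functional assay on HeLa cells (Homo sapiens) for inhibition, read by CCK-8 assay, with a stated time of 72 h, tested at 8 uM (a higher number here means more inhibition of growth at the concentration tested, a lower number less inhibition of growth), compound 1 gives 21.7% and compound 2 gives 21.9%; the step of a number 0.2 percentage points higher from compound 1 to compound 2 (within the scatter) stays within the scatter. Compound 3 gives 3.39% in this assay and stands lowest of the three numbers, with a number 18.3 percentage points lower from compound 1 to compound 3 (beyond the scatter) and a number 18.5 percentage points lower from compound 2 to compound 3 (beyond the scatter) both beyond the scatter and modest in size.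

Compound 4 `CC(C)(C)c1ccc(SCc2ccc(/C=C/C(=O)Nc3ccccc3N)cc2)cc1` is not yet measured. Its change from compound 3 is 4-(tert-butyl)phenyl in place of 3,5-dimethylphenyl on a sulfur. For the measured compounds named here, the steps that bear on this are a number 18.3 percentage points lower from compound 1 to compound 3 (beyond the scatter) and a number 18.5 percentage points lower from compound 2 to compound 3 (beyond the scatter), each a modest fall on moving from 4-methylphenyl or 3,4-dimethoxyphenyl to 3,5-dimethylphenyl. Compound 4 leaves 3,5-dimethylphenyl again, so the step is expected to run upward by roughly that size, a number 14.6 percentage points higher from compound 3 to compound 4 (beyond the scatter). From the compounds shown here alone, whether 4-(tert-butyl)phenyl behaves like 4-methylphenyl is untested, so the range is kept wide. Compound 4 is expected to give 18% in this assay, within 5% to 32%.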

Compound 4, percent growth inhibition at one concentration: 9.8%
Estimate against measurement, compound 4: 8.2 percentage points above; low and high end bracket the measured number.
By their numbers in this assay, from the lowest: compounds 3 and 4 (each within the scatter of the next); then compounds 1 and 2 (each within the scatter of the next).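

In this assay, tert-butyl in place of methyl on an aromatic carbon gives a number 11.9 percentage points lower from compound 1 to compound 4 (beyond the scatter), so the low numbers at this sulfur are not confined to 3,5-dimethylphenyl, and changing only the alkyl group on the ring is enough to produce a drop. 4-(tert-butyl)phenyl also reads lower than 3,4-dimethoxyphenyl, with a number 12.1 percentage points lower from compound 2 to compound 4 (beyond the scatter), while a number 6.4 percentage points higher from compound 3 to compound 4 (within the scatter) does not separate it from 3,5-dimethylphenyl, leaving two levels among the four compounds. No available evidence gives a reason for these steps.

The compounds shown leave open how a phenyl ring carrying an amine or a carboxylic acid would read on this sulfur. They also leave open whether a longer saturated chain in place of the aromatic ring would keep, lose or exceed the higher level of compound 1 and compound 2.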